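Urea alkyl variation in a thromboxane receptor antagonist series

The compounds below may be only part of what the source reports. "The series", "measured", "known", "first", "only" and "open" are said of these compounds alone.

compound 1 `CC(C)(C)NC(=O)NS(=O)(=O)c1cc(C#N)ccc1Oc1ccc(Br)cc1`: 5880 nM
compound 2 `Cc1ccccc1Nc1ccc(C#N)cc1S(=O)(=O)NC(=O)NC(C)C`: 7240 nM

In a functional assay on HEK293 cells for antagonist activity at thromboxane A2 receptor (Homo sapiens), read by fluorescence and calcium flux (a lower number here means a stronger inhibitor, a higher number a weaker inhibitor), compound 1 gives 5880 nM. In this assay compound 2 gives 7240 nM. Compound 2 holds the higher of the two numbers, but its gap to compound 1 lies within the scatter, so the two cannot be ordered. The two compounds also differ from each other in more than one place, so the pair says nothing about any single change.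

Compound 3 `Cc1ccccc1Nc1ccc(C#N)cc1S(=O)(=O)NC(=O)NC(C)(C)C` differs from compound 2 only by methyl in place of hydrogen on a saturated chain carbon bound to an amide-type nitrogen and two saturated chain carbons. Within the data shown here, no step between measured compounds isolates this change. Compound 1 also carries the tert-butyl group, but differs from compound 2 in other places as well, so it gives no clean reading. The expectation is therefore a step of a 1.3-fold lower number from compound 2 to compound 3 (0.12 log units; within the scatter) that stays within the scatter, with no direction that can be called. Compound 3 is estimated at 5500 nM, expected between 1800 nM and 17000 nM.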

Compound 3, half-maximal inhibitory concentration: 2750 nM
For compound 3 the middle estimate is 2.0-fold (0.30 log units) above the measured one, and the stated range covers the measured number.
By their numbers in this assay, from the lowest: compound 3; then compounds 1 and 2 (each within the scatter of the next).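

In this assay, among these compounds, isopropyl to tert-butyl gives a 2.6-fold lower number from compound 2 to compound 3 (0.42 log units; beyond the scatter), a modest change beyond the scatter and the first reading of this position free of any other difference. With tert-butyl held constant, (2-methylphenyl)amino in place of 4-bromophenoxy on an aromatic carbon gives a 2.1-fold lower number from compound 1 to compound 3 (0.33 log units; beyond the scatter), also modest and beyond the scatter, so a second place on the core moves the number as well. No measured evidence accounts for either step.

From the compounds shown here alone, whether cyclopropyl or a longer chain such as n-butyl at this place reads like isopropyl or like tert-butyl remains open. Also open, going by these compounds, is whether the methyl step holds on the core of compound 1, which would take the isopropyl partner of compound 1 to read.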